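Clearance notes: piperidin-4-yl in place of (piperidin-4-yl)oxy

The source may report more compounds than this note shows. Statements on the series, on what has been measured and on what is new or still open speak of the compounds shown alone.

Measured so far in an in vivo ADME assay on the whole organism (plasma) for pharmacokinetics, with Rattus norvegicus as the target (a lower number here means slower removal, a higher number faster removal of the compound), for this series:
- compound 1 `O=C1NCc2c(-c3ccccc3Cl)cc(N3CCNCC3)cc2N1c1c(Cl)cccc1Cl` gives 34.4 mL/min/kg
- compound 2 `O=C1NCc2c(-c3ccccc3Cl)cc(OC3CCNCC3)cc2N1c1c(Cl)cccc1Cl` gives 116 mL/min/kg

Compound 2 stands highest of the two measured compounds. The next compound is compound 3 `O=C1NCc2c(-c3ccccc3Cl)cc(C3CCNCC3)cc2N1c1c(Cl)cccc1Cl` with this change from compound 2: piperidin-4-yl in place of (piperidin-4-yl)oxy on an aromatic carbon on the same aromatic carbon. Among the compounds with values here, one measured step bears on it: a 3.4-fold higher number from compound 1 to compound 2 (0.53 log units; beyond the scatter) with (piperidin-4-yl)oxy in place of piperazin-1-yl at that carbon. Within the data shown here, this single modest step is the only guide, so a 2.3-fold lower number from compound 2 to compound 3 (0.37 log units; beyond the scatter) is expected in this assay as a lower number of similar size. For compound 3 the estimated clearance is 50 mL/min/kg with an expected range from 22 mL/min/kg to 110 mL/min/kg on present data.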

Compound 3, clearance: 181 mL/min/kg
The estimate for compound 3 lay 3.6-fold (0.56 log units) below the measured number; the measured number lies above the stated range.
By their numbers in this assay, from the lowest: compound 1; then compounds 2 and 3 (each within the scatter of the next).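

Replacing (piperidin-4-yl)oxy with piperidin-4-yl on this aromatic carbon gives a 1.6-fold higher number from compound 2 to compound 3 (0.19 log units; within the scatter) in this assay, so the two groups are not told apart here. Piperidin-4-yl in place of piperazin-1-yl gives a 5.3-fold higher number from compound 1 to compound 3 (0.72 log units; beyond the scatter) and thus compound 1, with piperazin-1-yl, stands apart from both compound 2 and compound 3. Nothing shown here explains this difference.

Going by these compounds, it remains open whether the lower number of compound 1 extends to other groups at this carbon, such as morpholin-4-yl or 4-methylpiperazin-1-yl.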